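This account rests on a few compounds, and the source may have more. Where it says the series, first, only, none or still open, it means among the compounds named here.

Compound 2 `CCC(C)OC(=O)C1=C(C)NC(=O)NC1c1cccs1` is the starting point here. Among the compounds with values here, in an assay on membranes from CHO cells for displacement of a labelled ligand from adenosine receptor A1 (Homo sapiens), read by scintillation counting, with a stated time of 60 min, tested at 1 uM (a lower number here means less inhibition, a higher number more inhibition at the concentration tested (going by the name of the read-out)), compound 2 gives 5%, the lower of the two numbers measured so far, though its nearest neighbour sits within the usual scatter. That neighbour is compound 1 `CCSC(=O)C1=C(C)NC(=O)NC1c1cccs1`, which in this assay gives 6%; the change from one to the other, sec-butoxy in place of ethylsulfanyl on a carbonyl carbon, gave a number 1 percentage points lower from compound 1 to compound 2 (within the scatter). The next compound, compound 3 `CC1=C(C(=O)OC2CCCCC2)C(c2cccs2)NC(=O)N1`, is to be measured in the same assay. It differs from compound 2 in one place: cyclohexyl in place of sec-butyl on an oxygen next to a carbonyl group. Within the data shown here, only one measured step is available, and it altered the group on the carbonyl carbon without moving the number beyond the scatter; both compounds sit near the bottom of the scale. A change of the group on the oxygen is therefore expected to leave compound 3 in this assay around 6%, between -5% and 18%, an expected step of a number 1 percentage points higher from compound 2 to compound 3 (within the scatter).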

Compound 3, a percentage reported as inhibition, at one concentration (the size of the read-out at that concentration, not a potency): 7%
For compound 3 the middle estimate is 1 percentage points below the measured one; the measured number falls inside the stated range.
By their numbers in this assay, from the lowest: compounds 2, 1 and 3 (each within the scatter of the next).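

Putting cyclohexyl in place of sec-butyl on an oxygen next to a carbonyl group gives a number 2 percentage points higher from compound 2 to compound 3 (within the scatter) in this assay. Exchanging a chain for a six-membered ring of carbon at this position therefore does not separate the two compounds, and the same holds for the larger swap of ethylsulfanyl for cyclohexyloxy on a carbonyl carbon, which gives a number 1 percentage points higher from compound 1 to compound 3 (within the scatter). All three compounds stay near the bottom of the scale, and no outside information bears on this result.

As far as these compounds go, whether a benzyl group or a chain ending in an amine on this oxygen would move the number beyond the scatter remains open. From the compounds shown here alone, the effect of changes elsewhere on the shared core is also open.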